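The compounds below may be only part of what the source reports. "The series", "measured", "known", "first", "only" and "open" are said of these compounds alone.

Values in an ADME assay for permeability, using PAMPA, at pH 7.4; on this read-out higher numbers stand for higher permeability and lower numbers for lower permeability:
- compound 1 `CSc1ccc(NC(=O)Nc2cc(C)nc3ccccc23)cc1`: 473 10^-6 cm/s
- compound 2 `CC(=O)c1ccc(NC(=O)Nc2cc(C)nc3ccccc23)cc1`: 473 10^-6 cm/s
- compound 3 `Cc1cc(NC(=O)Nc2ccc(N(C)C)cc2)c2ccccc2n1`: 2 10^-6 cm/s

Compound 3 stands lowest of the three, as shown by a 240-fold lower number from compound 1 to compound 3 (2.37 log units; beyond the scatter) and a 240-fold lower number from compound 2 to compound 3 (2.37 log units; beyond the scatter). Compound 4 `COC(=O)c1ccc(NC(=O)Nc2cc(C)nc3ccccc23)cc1` carries methoxycarbonyl in place of dimethylamino on an aromatic carbon, para to a large group (methoxycarbonyl in place of dimethylamino on an aromatic carbon). For the measured compounds named here, no methoxycarbonyl compound has been measured. The nearest guide is acetyl in compound 2, which also has a carbonyl, and no change at the digits printed from compound 1 to compound 2 (within the scatter) shows that the two groups measured at this place other than dimethylamino sit level. In this assay a large rise is therefore expected, a 180-fold higher number from compound 3 to compound 4 (2.24 log units; beyond the scatter). The estimate for compound 4 is 350 10^-6 cm/s, with an expected range of 100 10^-6 cm/s to 700 10^-6 cm/s.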

Compound 4, apparent permeability: 448 10^-6 cm/s
Estimate against measurement, compound 4: 1.3-fold (0.11 log units) below, within the range that was stated.
By their numbers in this assay, from the lowest: compound 3; then compounds 4, 1 and 2 (each within the scatter of the next).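

In this assay, methoxycarbonyl in place of dimethylamino on this aromatic carbon gives a 220-fold higher number from compound 3 to compound 4 (2.35 log units; beyond the scatter), so a second carbonyl group joins the high level. Methoxy in place of methyl on the carbonyl carbon changes little, with a 1.1-fold lower number from compound 2 to compound 4 (0.02 log units; within the scatter), and the comparison with methylsulfanyl reads the same, with a 1.1-fold lower number from compound 1 to compound 4 (0.02 log units; within the scatter). Compound 3 alone stands apart from the other three, and no measurement at hand accounts for the gap.

Still open, going by these compounds, is whether a primary amine or a morpholine at this place sits as low as compound 3. Also open, on these data alone, is whether a carboxylic acid stays with compounds 1, 2 and 4.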